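Swapping Isopropyl for Diethylamino on a Sulfonyl Sulfur

This account rests on a few compounds, and the source may have more. Where it says the series, first, only, none or still open, it means among the compounds named here.

Measured so far:
Compound 1, `CC(C)c1noc(N2CCN(C(=O)[C@@H]3CCCN(S(=O)(=O)c4ccc(S(=O)(=O)C(C)C)cc4)C3)CC2)n1`: in a functional assay on MIA PaCa-2 cells (Homo sapiens) for inhibition, read by MTT assay, with a stated time of 7 days (a lower number here means a stronger inhibitor, a higher number a weaker inhibitor), compound 1 gives 70 nM.
Compound 2, `CCOC(=O)C12CC(CN(S(=O)(=O)c3ccc(S(=O)(=O)N(CC)CC)cc3)C1)C2`: in this assay compound 2 gives 1000 nM.

Two compounds have numbers in this assay. Compound 1 has the lower of the two, and the gap to compound 2 lies beyond the scatter; compound 2 differs from compound 1 in more than one place, so the two values can only be read side by side, not as a single step.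

Compound 3, `CCN(CC)S(=O)(=O)c1ccc(S(=O)(=O)N2CCC[C@@H](C(=O)N3CCN(c4nc(C(C)C)no4)CC3)C2)cc1`, keeps the whole of compound 1 apart from one change: diethylamino in place of isopropyl on a sulfonyl sulfur. For the measured compounds named here, nothing in the measured pairs isolates this change, so no measured step sets its size. Both groups are small, uncharged and carry neither donors nor acceptors. A modest movement in this assay is expected, if any beyond the scatter, and a slight drift towards a higher number seems the more likely outcome.

For compound 3 the expected step is a 1.6-fold higher number from compound 1 to compound 3 (0.20 log units; within the scatter). Compound 3 is estimated at 110 nM, with a range from 35 nM to 400 nM.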

Compound 3, half-maximal inhibitory concentration: 50 nM
Compound 3: middle estimate off by 2.2-fold (0.34 log units), on the high side; the measured number falls inside the stated range.
By their numbers in this assay, from the lowest: compounds 3 and 1 (each within the scatter of the next); then compound 2.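

For the compounds shown here, this is the first comparison in which only this position changes. In this assay, putting diethylamino in place of isopropyl on a sulfonyl sulfur gives a 1.4-fold lower number from compound 1 to compound 3 (0.15 log units; within the scatter), so the two groups cannot be told apart in this cell read-out. The position therefore accepts a move from isopropylsulfonyl to diethylsulfamoyl, which takes the group from 3 heavy atoms to 5 and brings in a nitrogen, with no measurable difference, though nothing shown explains this result.

From the compounds shown here alone, both groups have no ring, no net charge and no hydrogen-bond donors, so it remains open how the position would respond to a ring such as morpholine, a carboxylic acid, a primary amine or a much smaller group such as methyl. It is also unknown whether the same swap would be as uneventful on a different core, since this single pair shows it only on the core of compound 1.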